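Working notes: from compound 2 to compound 3

The compounds below may be only part of what the source reports. "The series", "measured", "known", "first", "only" and "open" are said of these compounds alone.

- compound 1 `COC(=O)c1ccc(/N=N/N(C)C(=O)CCc2cccc(O)c2)cc1` gives 94.7 h
- compound 2 `CN(/N=N/c1ccc(C#N)cc1)C(=O)CCCCc1ccc(O)cc1` gives 82.5 h

In a physicochemical assay for metabolic stability, read by HPLC, in phosphate buffer, at pH 7.4 (a lower number here means that the compound disappears faster, a higher number that the compound lasts longer), compound 2 cannot be told apart from compound 1, as the two numbers lie within the scatter. Compound 3 `COC(=O)c1ccc(/N=N/N(C)C(=O)CCCCc2ccc(O)cc2)cc1` carries methoxycarbonyl in place of cyano on an aromatic carbon, para to a large group (methoxycarbonyl in place of cyano on an aromatic carbon). No measured pair differs in one place only, so the size of this step has not been shown directly. Compound 1 also carries methoxycarbonyl and gives 94.7 h in the same measurement, so no step beyond the scatter is expected in this assay. The estimated change is a 1.1-fold higher number from compound 2 to compound 3 (0.04 log units; within the scatter) and stays within the scatter. For compound 3 the expected half-life is 90 h (estimated range 50 h to 160 h).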

Compound 3, half-life: 124 h
Compound 3: middle estimate off by 1.4-fold (0.14 log units), on the low side, within the range that was stated.
By their numbers in this assay, from the lowest: compounds 2, 1 and 3 (each within the scatter of the next).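

In this assay, among these compounds, the first one-place comparison at this aromatic carbon, para to a large group, is a 1.5-fold higher number from compound 2 to compound 3 (0.18 log units; within the scatter), so methoxycarbonyl in place of cyano gives no step beyond the scatter. At the saturated chain carbon, 2-(4-hydroxyphenyl)ethyl in place of 3-hydroxyphenyl gives a 1.3-fold higher number from compound 1 to compound 3 (0.12 log units; within the scatter), which also stays within the scatter. Nothing available bears on either step.

Still open, from the compounds shown here alone, is whether a carboxylic acid or an amine on this aromatic carbon would give a step beyond the scatter, and whether a longer chain would.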